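Compound 1 to compound 4: working notes on the series

A few compounds are considered here, and "the series" means these few. Any claim that something is new, unique, unknown or untested is made for them only; others in the source may bear on it.

compound 1 `CC(C)CCN(C)Cc1ccc(C2=CCCN(C)C2)cc1`: > 50000 nM (a limit)
compound 2 `CN1CCC=C(c2ccc(CN(C)Cc3ccc(Cl)cc3)cc2)C1`: > 50000 nM (a limit)
compound 3 `CN1CCC=C(c2ccc(CN(C)C/C=C/c3ccccc3)cc2)C1`: > 50000 nM (a limit)

In an ADME assay on HL-60 cells (Homo sapiens) for cytotoxicity, read by MTT assay, with a stated time of 24 h (a higher number here means a weaker inhibitor, a lower number a stronger inhibitor), compound 1 gives > 50000 nM, which is a limit of the assay and not a number. Compound 2 and compound 3 also have limits only. What the series offers so far is the limit of > 50000 nM in this assay, at which 3 of the 3 values shown sit.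

Compound 4 `CC(C)CCN(C)Cc1ccc(C2CCCN(C)C2)cc1` differs from compound 1 in a single group on an aromatic carbon: a group of 7 heavy atoms (6 carbon, 1 nitrogen; one six-membered non-aromatic ring with 1 hetero atom) in place of a group of 7 heavy atoms (6 carbon, 1 nitrogen; one six-membered non-aromatic ring with 1 hetero atom), on an aromatic carbon. The group that enters is 1-methylpiperidin-3-yl, and the group that leaves carries a double bond outside aromatic rings.

The measured steps bear on this only loosely, since each changes a group on a saturated chain carbon bound to an amine nitrogen. They are a step that the two limits leave unreadable from compound 1 to compound 2, a step that the two limits leave unreadable from compound 1 to compound 3 and a step that the two limits leave unreadable from compound 2 to compound 3. None has a readable size, and none touches the place that changes in compound 4. No step beyond the scatter is therefore expected in this assay, and no direction is expected. That expectation rests on compound 1, whose > 50000 nM is a limit. The estimated change is a step that the limit leaves unreadable from compound 1 to compound 4. For compound 4 the estimate is 60000 nM, with an expected range from 25000 nM to 150000 nM, and a report of a limit alone is expected as the likeliest outcome.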

Compound 4, half-maximal inhibitory concentration: > 50000 nM
Compound 4 was reported as a limit; the forecaster's own chance of this, stated with the estimate: 85%; the middle value lies beyond the limit too.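

In this assay compound 4 gives > 50000 nM, which is a limit and not a number. Compound 1 also has only a limit, so no new step can be read between compound 1 and compound 4. The compounds shown leave open whether the 1-methylpiperidin-3-yl group differs at all from the group it replaces, as the series offers only this: the limit of > 50000 nM in this assay, at which 4 of the 4 values shown sit.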